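The source may hold more compounds than are shown below. What is called first, only, known or untested is meant among the compounds shown, and "the series" means these compounds.

Compound 1 `O=S(=O)(Nc1cccc2cc[nH]c12)c1ccc(Cl)cc1` and compound 2 `O=S(=O)(Nc1cc(Cl)cc2cc[nH]c12)c1ccc(Cl)cc1` share one core; compound 2 differs from compound 1 by chloro in place of hydrogen on an aromatic carbon. In a functional assay on P388 cells (Mus musculus) for antiproliferative activity, read by colorimetric assay and MTT assay (a higher number here means a weaker inhibitor, a lower number a stronger inhibitor), compound 1 gives 6 ug/mL and compound 2 gives 9.9 ug/mL; the step is a 1.7-fold higher number from compound 1 to compound 2 (0.22 log units; within the scatter), so the two values are not separated.

Compound 3 `N#Cc1ccc(S(=O)(=O)Nc2ccc(Cl)c3cc[nH]c23)cc1` rests on a different core; the difference between the core of compound 1 and the core of compound 3 is not broken down here. In this assay compound 3 gives 1.8 ug/mL, the lowest of the three measured numbers, and its gaps to compound 1 and to compound 2 are both beyond the scatter.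

Compound 4 `N#Cc1ccc(S(=O)(=O)Nc2ccc(Cl)c3c(Cl)c[nH]c23)cc1` is not yet measured. It differs from compound 3 by chloro in place of hydrogen on an aromatic carbon. This is the same kind of change as that from compound 1 to compound 2, not the same change: there the chloro entered on an aromatic carbon of a six-membered aromatic ring of carbon only, meta to a fused ring, meta to a large group and para to a fused ring; here it enters on an aromatic carbon of a five-membered aromatic ring with one nitrogen, two ring bonds from the ring nitrogen. Among the compounds with values here, the only measured precedent, a 1.7-fold higher number from compound 1 to compound 2 (0.22 log units; within the scatter), lies within the scatter, and that precedent is the sole basis for what follows. A step of a 1.4-fold higher number from compound 3 to compound 4 (0.14 log units; within the scatter) is expected, taken from a 1.7-fold higher number from compound 1 to compound 2 (0.22 log units; within the scatter) and widened for the different place. For compound 4 the estimate in this assay is 2.5 ug/mL, with a range from 1 ug/mL to 6.5 ug/mL.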

Compound 4, half-maximal inhibitory concentration: 0.59 ug/mL
Compound 4: middle estimate off by 4.2-fold (0.63 log units), on the high side; measured number outside the range, below it.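

In this assay, chloro in place of hydrogen on an aromatic carbon gives a 3.1-fold lower number from compound 3 to compound 4 (0.48 log units; beyond the scatter), so the earlier step does not carry over to this core as a guide to either size or direction: the same change on two cores in this assay, a 1.7-fold higher number (0.22 log units; within the scatter) from compound 1 to compound 2 and a 3.1-fold lower number (0.48 log units; beyond the scatter) from compound 3 to compound 4, 5.0-fold (0.70 log units) apart, beyond the scatter of two such steps

This does not isolate the core as the source of the difference, since the two steps also differ in place: in compound 2 the chloro stands on a six-membered aromatic ring of carbon only, and in compound 4 on a five-membered aromatic ring with one nitrogen, two ring bonds from the ring nitrogen. Within the data shown here, with a single pair on each core, the data show only that these two steps disagree, and they set no rule for chloro, nor do they show what chloro would do at either place on the other core.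

As far as these compounds go, it remains open whether a methyl group, a bromo group or an amine on that same carbon of the five-membered ring would shift the number as chloro does. Also open, from the compounds shown here alone, is whether the step holds when the nitrile of compound 3 is replaced by a carboxylic acid or an amide.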